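Mirror image of a dimethylamino cyclohexane at the sigma-2 site

This account rests on a few compounds, and the source may have more. Where it says the series, first, only, none or still open, it means among the compounds named here.

Compound 1 `CN(C)CC[C@H]1CCC[C@@H](c2ccccc2)C1` gives 156 nM in an assay on membranes from liver for displacement of a labelled ligand from Sigma intracellular receptor 2 (Rattus norvegicus), read by scintillation counting, with a stated time of 120 min (a higher number here means a weaker inhibitor, a lower number a stronger inhibitor), the highest of the two single numbers shown. Its nearest neighbour is compound 3 `c1ccc(CNCC[C@H]2CCC[C@H](c3ccccc3)C2)cc1`, which in this assay gives 46 nM, a gap beyond the scatter. Compound 2 `c1ccc(CNCC[C@@H]2CCC[C@@H](c3ccccc3)C2)cc1` gives 268 nM; 57 nM (2 entries) in this assay, with no single number. Compound 4 `CN(C)CC[C@@H]1CCC[C@H](c2ccccc2)C1` differs from compound 1 as follows: the two compounds have the same atoms and bonds and differ only in configuration as drawn: 2 of 2 stereo elements differ (all stereocentres are inverted: mirror images); a stereocentre at a saturated ring carbon is drawn S in compound 1 and R in compound 4; a stereocentre at a saturated ring carbon is drawn R in compound 1 and S in compound 4. No measured step of this kind exists among the shown compounds, though the fact that compounds 2 and 3 differ only in the configuration as drawn together with the several entries of compound 2 in this assay, 268 nM; 57 nM (2 entries) suggests that such a mirror-image pair need not differ beyond the scatter. He therefore expects the step of a 1.1-fold lower number from compound 1 to compound 4 (0.05 log units; within the scatter) to stay within the scatter. For compound 4 he estimates 140 nM in this assay, in the range 45 nM to 450 nM.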

Compound 4, inhibition constant: 76 nM
For compound 4 the middle estimate is 1.8-fold (0.27 log units) above the measured one; low and high end bracket the measured number.
By their numbers in this assay, from the lowest: compounds 3 and 4 (each within the scatter of the next); then compound 1.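

In this assay the mirror-image change gives a single readable step with nothing but configuration altered, a 2.1-fold lower number from compound 1 to compound 4 (0.31 log units; beyond the scatter). Inverting both stereocentres therefore moves the number on the dimethylamino compounds, though only modestly and just past the scatter. The earlier pair could not show this, as compound 2 has no single number: the several entries of compound 2 in this assay, 268 nM; 57 nM (2 entries)

Going by these compounds, whether compound 2 and compound 3 differ in the same direction stays open. So does the effect of a primary amine or a longer chain in place of the dimethylamino group in either mirror-image form.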